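The compounds below may be only part of what the source reports. "The series", "measured", "known", "first", "only" and "open" are said of these compounds alone.

Working notes on the series. Three measured members share one core. Compound 1 `COc1ccccc1NC(=O)NC1CC(C)(C)Oc2ccc(Cl)cc21` carries a 2-methoxyphenyl on an amide-type nitrogen, compound 2 `COc1cccc(NC(=O)NC2CC(C)(C)Oc3ccc(Cl)cc32)c1` a 3-methoxyphenyl, and compound 3 `COc1ccc(NC(=O)NC2CC(C)(C)Oc3ccc(F)cc32)cc1` a methoxyphenyl together with fluoro in place of the chloro of the first two. In a functional assay (aorta) with Rattus norvegicus as the target (on this read-out higher numbers stand for an effect only at larger amounts of compound and lower numbers for an effect already at smaller amounts), compound 1 reaches only a limit of the assay, > 10000 nM. In this assay compound 2 likewise reports only a limit, > 10000 nM. Within the data shown here, compound 3 gives a number in this assay, 15500 nM, and is thus the only member with a numerical read-out. The step that the two limits leave unreadable from compound 1 to compound 2 is unreadable, both of its ends sitting at the limit (the limit of > 10000 nM in this assay, at which 2 of the 3 values shown sit).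

Compound 4 `COc1ccc(NC(=O)NC2CC(C)(C)Oc3ccc(Cl)cc32)cc1` differs from compound 3 by chloro in place of fluoro on an aromatic carbon. Among the measured compounds shown here, no measured step covers this exchange; the one measured step, between compounds 1 and 2, changes the methoxyphenyl, not this position, and yields no size. The step of a 1.3-fold lower number from compound 3 to compound 4 (0.11 log units; within the scatter) for compound 4 is therefore expected to stay within the usual scatter, with no direction assigned. Compound 4 is estimated at 12000 nM in this assay, in a range from 4000 nM to 40000 nM, with a fair chance that only a limit is reported.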

Compound 4, half-maximal effective concentration: > 30000 nM
Compound 4 ended at the assay's limit (the forecaster's own chance of this, stated with the estimate: 40%); middle value at least 2.5-fold (0.39 log units) from the limit.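

Among these compounds, the exchange of fluoro for chloro on this aromatic carbon gives the only step with a readable size, and that size is a floor: an at least 1.9-fold higher number from compound 3 to compound 4 (0.28 log units; that floor lies within the scatter) in this assay. The floor alone does not separate the two compounds beyond the scatter, so a higher number for chloro is suggested but not established, and the true step may be larger, since compound 4 reports only a limit: the limit of > 30000 nM in this assay, at which 1 of the 4 values shown sits. Among the compounds shown here, the steps from compound 1 and compound 2 to compound 4, which change the methoxyphenyl with chloro held in place, cannot be read, so the methoxyphenyl change still has no size and compound 3 remains the only member with a number.

Open, going by these compounds, is how far the number for compound 4 lies beyond the limit, and whether a bromo, a methyl or a nitrile on the same aromatic carbon would give a number at all. Also open, on these data alone, is how the 2-methoxyphenyl and 3-methoxyphenyl groups would read with fluoro on that carbon, and whether an amine or a carboxylic acid in place of the methoxy would bring a numerical read-out.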